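The compounds below may be only part of what the source reports. "The series", "measured", "known", "first", "only" and "open" are said of these compounds alone.

Measured so far:
Compound 1, `Cc1c(OCCCCOc2ccc(C(=O)O)cc2F)ccc(C(=O)CC2CCCC2)c1O`: 639 nM
Compound 2, `Cc1c(OCCCCOc2ccc(C(=O)O)cc2F)ccc(C(=O)CC(C)C)c1O`: 102 nM
Compound 3, `CCCC(=O)c1ccc(OCCCCOc2ccc(C(=O)O)cc2C)c(C)c1O`: 104 nM

All three were tested in an assay on HEK293 cells for positive allosteric modulation of metabotropic glutamate receptor 2 (Rattus norvegicus), read by thallium flux, with a stated time of 2.5 min; on this read-out lower numbers stand for an effect already at smaller amounts and higher numbers for an effect only at larger amounts of compound. Compound 2 gives the lowest number of the three. Within the data shown here, compound 3 lies within the scatter of it, so the two cannot be told apart, while compound 1 sits beyond the scatter: the change a 6.3-fold lower number from compound 1 to compound 2 (0.80 log units; beyond the scatter) is the only single-point step among the measured compounds, and it concerns the chain on the carbonyl, not the ring that changes next.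

Compound 4, `Cc1c(OCCCCOc2ccc(C(=O)O)cc2Cl)ccc(C(=O)CC(C)C)c1O`, differs from compound 2 in one place: chloro in place of fluoro on an aromatic carbon. Among the measured compounds shown here, no measured step touches this part of the molecule directly. For the measured compounds named here, the only hint comes from compound 3, which carries a methyl in place of the fluoro but also a different chain on its carbonyl; its value and that of compound 2 fall within the scatter of each other, suggesting that a small change here is tolerated, though the comparison is not a clean one.

Compound 4 is therefore expected to stay within the scatter of compound 2, with the expected step of a 1.0-fold lower number from compound 2 to compound 4 (0.01 log units; within the scatter). The estimate for compound 4 is 100 nM, with a range from 40 nM to 250 nM.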

Compound 4, half-maximal effective concentration: 96 nM
Beside the measured number, compound 4's estimate is 1.0-fold (0.02 log units) above it; low and high end bracket the measured number.
By their numbers in this assay, from the lowest: compounds 4, 2 and 3 (each within the scatter of the next); then compound 1.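

Chloro in place of fluoro, on an aromatic carbon ortho to a large group and meta to a carboxy group, gives in this assay a 1.1-fold lower number from compound 2 to compound 4 (0.03 log units; within the scatter), so the two compounds cannot be told apart. Among these compounds, this is the first direct reading at this position, since the rest of the molecule stays the same and only the halogen differs, and it shows that the 4-carboxy-2-fluorophenyl and 4-carboxy-2-chlorophenyl versions read alike here. Nothing measured alongside this result explains why the exchange leaves the number within the scatter.

From the compounds shown here alone, only these two halogens have been compared in one-place steps at this position, so it remains open whether a bare hydrogen, a methoxy group, a nitrile or an amine on this carbon would also leave the number within the scatter. Going by these compounds, it is also open whether the same exchange would read alike with the cyclopentyl group of compound 1 in place of the isopropyl group carried by compound 2 and compound 4.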